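The source may report more compounds than this note shows. Statements on the series, on what has been measured and on what is new or still open speak of the compounds shown alone.

Measured compounds:
- compound 1 `O=C(OC1(C(=O)Nc2ccc([N+](=O)[O-])cc2)CCCCC1)c1ccc(C(F)(F)F)cc1` — 26 nM
- compound 2 `Cc1ccc(C(=O)OC2(C(=O)Nc3ccc([N+](=O)[O-])cc3)CCCCC2)cc1` — 45.4 nM
- compound 3 `O=C(OC1(C(=O)Nc2ccc([N+](=O)[O-])cc2)CCCCC1)c1ccc(Br)cc1` — 236 nM

In a functional assay on NFS-60 cells (Mus musculus) for inhibition, read by MTT assay, with a stated time of 72 h (on this read-out higher numbers stand for weaker inhibition and lower numbers for stronger inhibition), compound 3 stands highest of the three numbers. Against its nearest neighbour the step of a 5.2-fold higher number from compound 2 to compound 3 (0.72 log units; beyond the scatter) lies beyond the scatter, and against the furthest the step of a 9.1-fold higher number from compound 1 to compound 3 (0.96 log units; beyond the scatter) is larger still. The remaining pair, a 1.7-fold higher number from compound 1 to compound 2 (0.24 log units; within the scatter), sits within the scatter, so compound 1 and compound 2 cannot be ordered against each other.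

Compound 4 `O=C(OC1(C(=O)Nc2ccc([N+](=O)[O-])cc2)CCCCC1)c1ccc([N+](=O)[O-])cc1` alters only the group on the ester side: nitro in place of bromo on an aromatic carbon. Among the measured compounds shown here, no measured step exchanges bromo for nitro, and no measured compound carries nitro at this position, so the expectation rests on the two steps that end at compound 3. Both show that exchanging the group on this aromatic carbon moves the number by a modest amount, and in both bromo gave the higher number. A move of comparable size in the downward direction is therefore expected for compound 4, though with wide uncertainty, since neither of the groups already seen resembles nitro in what it counts.

Compound 4 is estimated at 70 nM in this assay, with a range of 15 nM to 300 nM, meaning an expected step of a 3.4-fold lower number from compound 3 to compound 4 (0.53 log units; beyond the scatter).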

Compound 4, half-maximal inhibitory concentration: 7.7 nM
Compound 4: the middle estimate sits 9.1-fold (0.96 log units) above what was measured; measured number outside the range, below it.
By their numbers in this assay, from the lowest: compound 4; then compounds 1 and 2 (each within the scatter of the next); then compound 3.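

In this assay, the 4-bromophenyl to 4-nitrophenyl change gives the largest step seen at this position (a 31-fold lower number from compound 3 to compound 4 (1.49 log units; beyond the scatter)), exceeding the largest earlier step (a 9.1-fold higher number from compound 1 to compound 3 (0.96 log units; beyond the scatter)), so this aromatic carbon tolerates a wider span of numbers than the first three compounds revealed. The earlier compounds shown here left methyl and trifluoromethyl unordered at the low end, whereas nitro falls beyond the scatter from both (a 5.9-fold lower number from compound 2 to compound 4 (0.77 log units; beyond the scatter); a 3.4-fold lower number from compound 1 to compound 4 (0.53 log units; beyond the scatter)), which makes compound 4 the most potent of the four in this read-out and shows that the low end had not been reached. With bromo leaving and nitro entering, the exchange adds two hydrogen-bond acceptors and two heavy atoms, but no available data bear on what lies behind the drop in the number.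

Going by these compounds, the four groups give no simple order, and whether a nitrile, a carboxylic acid or an amine at this position would follow nitro or fall elsewhere remains open. Also open, on these data alone, is whether the low number of compound 4 depends on the nitro group on the other aromatic ring of the shared core.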